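Swapping amino for methyl on an aryl guanidine

This account rests on a few compounds, and the source may have more. Where it says the series, first, only, none or still open, it means among the compounds named here.

Measured so far:
compound 1 `CC1(C)Oc2ccc(C#N)cc2[C@@H](/N=C(\NC#N)Nc2ccc(N)cc2)[C@@H]1O`: 3500 nM
compound 2 `CC1(C)Oc2ccc(C#N)cc2[C@@H](n2cc(C#N)c3ccccc32)[C@@H]1O`: 2200 nM

In a functional assay (aorta) with Rattus norvegicus as the target (a lower number here means a stronger inhibitor, a higher number a weaker inhibitor), compound 1 gives 3500 nM, which stands as the higher of the two numbers recorded, while compound 2 gives 2200 nM. The gap between them lies within the usual scatter of this assay, so neither compound can be called the stronger inhibitor on these numbers alone. Compound 3 `Cc1ccc(N/C(=N/[C@@H]2c3cc(C#N)ccc3OC(C)(C)[C@H]2O)NC#N)cc1` has not yet been measured in this assay. It differs from compound 1 in one place: methyl in place of amino on an aromatic carbon. Within the data shown here, no measured pair of compounds shows what this particular change does, so there is no known step to lean on. Among the measured compounds shown here, with only the single value of compound 1 as a starting point and no comparable pair to guide the direction, the expectation for compound 3 is a step of no clear direction, small enough that it may well stay within the scatter. Compound 3 is therefore estimated at 3000 nM in this assay, with a range from 900 nM to 10000 nM. The expected step of a 1.2-fold lower number from compound 1 to compound 3 (0.07 log units; within the scatter) is accordingly close to none.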

Compound 3, half-maximal inhibitory concentration: 2700 nM
Estimate against measurement, compound 3: 1.1-fold (0.05 log units) above; measured number inside the range.
By their numbers in this assay, from the lowest: compounds 2, 3 and 1 (each within the scatter of the next).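

Among these compounds, putting methyl in place of amino on this aromatic carbon, para to a large group, is the first single change that can be read here. Measured in this assay the swap gives a 1.3-fold lower number from compound 1 to compound 3 (0.11 log units; within the scatter) and so leaves the two compounds indistinguishable, even though the amino group counts one hydrogen-bond donor and one acceptor and the methyl group counts neither. At this position in the core of compound 1, then, this assay's read-out does not separate the two groups, and nothing available offers an explanation for that result.

What the compounds shown leave open is how far this tolerance extends, since only amino and methyl can be compared at this position, and a carboxylic acid, a methoxy group, a chlorine atom or a longer chain could give a quite different number. They also leave open whether the same swap would read the same way on a different core, or with the group placed elsewhere on the six-membered aromatic ring.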